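From fluoro to chloro on a compound at the limit

The source may report more compounds than this note shows. Statements on the series, on what has been measured and on what is new or still open speak of the compounds shown alone.

Compound 1 `CCOC(=O)c1c(-c2cccc(-c3ccccc3)c2)[nH]c2cc(OC)c(F)cc2c1=O` gives > 21500 nM
Compound 2 `CCOC(=O)c1c(-c2cccc(F)c2)[nH]c2cc(OC)c(F)cc2c1=O` gives > 21500 nM

In an ADME assay on Raji cells (Homo sapiens) for cytotoxicity, read by luminescence, with a stated time of 72 h (a higher number here means that more compound is needed for the effect, a lower number that less compound is needed), compound 2 gives > 21500 nM and this is a limit of the assay, not a number. Compound 1 likewise gives > 21500 nM as a limit. The data therefore show only the limit of > 21500 nM in this assay, at which 2 of the 2 values shown sit, and no number to work from.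

Compound 3 `CCOC(=O)c1c(-c2cccc(Cl)c2)[nH]c2cc(OC)c(F)cc2c1=O` carries chloro in place of fluoro on an aromatic carbon. Within the data shown here, the one measured step that bears on this is a step that the two limits leave unreadable from compound 1 to compound 2 so no size can be carried over from it. No step beyond the scatter is expected in this assay and another limit is likely. The expected change is a number no higher from compound 2 to compound 3 (the limit leaves the size open) as estimated here. For compound 3 the estimated value is 21500 nM (expected range 9000 nM to 40000 nM).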

Compound 3, half-maximal effective concentration: > 21500 nM
Compound 3 was reported as a limit; the forecaster's own chance of this, stated with the estimate: 80%; the middle value lies on the limit itself.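

Compound 1, compound 2 and compound 3 are each reported only as a limit, so no step among them can be read: the limit of > 21500 nM in this assay, at which 3 of the 3 values shown sit.

The compounds shown leave open how much of each is actually needed for the effect, and whether chloro in place of fluoro changes that amount.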